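Methoxy to Methyl: From Compound 3 to Compound 4

The source may hold more compounds than are shown below. What is called first, only, known or untested is meant among the compounds shown, and "the series" means these compounds.

In a functional assay on HeLa cells (Homo sapiens) for inhibition, read by CCK-8 assay, with a stated time of 72 h, tested at 2 uM (a lower number here means less inhibition of growth, a higher number more inhibition of growth at the concentration tested), compound 1 `Nc1ccccc1NC(=O)/C=C/c1ccc(CSc2ccc(Cl)cc2)cc1` gives 1.94%, compound 2 `Nc1ccccc1NC(=O)/C=C/c1ccc(CSc2cccc(F)c2)cc1` gives 2.25% and compound 3 `COc1ccc(SCc2ccc(C(=O)Nc3ccccc3N)cc2)cc1` gives 35%, the highest of the three and beyond the scatter of both others. Compound 4 `Cc1ccc(SCc2ccc(C(=O)Nc3ccccc3N)cc2)cc1` carries methyl in place of methoxy on an aromatic carbon, para to a large group (methyl in place of methoxy on an aromatic carbon). Among the compounds with values here, the only measured step that bears on this, 3-fluorophenyl in place of 4-chlorophenyl on a sulfur, is a number 0.3 percentage points higher from compound 1 to compound 2 (within the scatter). It stands on a different core from compound 3, so it guides only loosely. No change beyond the scatter is therefore expected. The estimated step is a number 5 percentage points lower from compound 3 to compound 4 (within the scatter). Compound 4 is expected at 30%, within a range from 12% to 50%.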

Compound 4, percent growth inhibition at one concentration: 33.8%
The estimate for compound 4 lay 3.8 percentage points below the measured number; the measured number falls inside the stated range.
By their numbers in this assay, from the lowest: compounds 1 and 2 (each within the scatter of the next); then compounds 4 and 3 (each within the scatter of the next).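

In this assay, methyl in place of methoxy on this aromatic carbon, para to a large group, gives a number 1.2 percentage points lower from compound 3 to compound 4 (within the scatter). The 4-methoxyphenyl to 4-methylphenyl change therefore removes one oxygen and the hydrogen-bond acceptor counted on methoxy without moving the number beyond the scatter. Nothing measured here explains why the number holds. What the compounds shown leave open is whether an amine or a carboxylic acid on the same aromatic carbon would keep growth inhibition at this level.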